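The source may report more compounds than this note shows. Statements on the series, on what has been measured and on what is new or still open speak of the compounds shown alone.

Measured so far in an ADME assay on the whole organism with Oryza sativa as the target, tested at 0.1 uM; a higher number here means a weaker effect of the compound at the concentration tested, a lower number a stronger effect:
- compound 1, `Cc1ccccc1NC(=O)N[C@H](C)c1ccccc1`: 100%
- compound 2, `C[C@@H](NC(=O)Nc1ccccc1C(F)(F)F)c1ccccc1`: 99%
- compound 3, `COc1ccccc1NC(=O)N[C@H](C)c1ccccc1`: 100%

Compound 3 is level with compound 1 at the digits shown, and compound 2 lies within the scatter of both: no change at the digits printed from compound 1 to compound 3 (within the scatter); a number 1 percentage points higher from compound 2 to compound 3 (within the scatter). The step to compound 4, `CC(=O)c1ccccc1NC(=O)N[C@H](C)c1ccccc1`, is acetyl in place of methoxy on an aromatic carbon. Among the compounds with values here, no measured step exchanges a methoxy for an acetyl, so the closest guides are the methyl-to-methoxy and trifluoromethyl-to-methoxy steps above, both within the scatter. Three different groups at this position gave no movement in this assay, so no step beyond the scatter is expected for compound 4 either; the estimated step is a number 1 percentage points lower from compound 3 to compound 4 (within the scatter). Compound 4 is expected to give 99% in this assay, within 90% to 100%.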

Compound 4, a percentage reported as activity, at one concentration (the size of the read-out at that concentration, not a potency): 96%
Compound 4: middle estimate off by 3 percentage points, on the high side; the range from low to high includes it.
By their numbers in this assay, from the lowest: compounds 4, 2, 1 and 3 (each within the scatter of the next).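

In this assay, acetyl also stays within the scatter at this position: a number 4 percentage points lower from compound 3 to compound 4 (within the scatter), a number 3 percentage points lower from compound 2 to compound 4 (within the scatter) and a number 4 percentage points lower from compound 1 to compound 4 (within the scatter). A fourth group on this aromatic carbon, ortho to a large group and bringing a double bond outside aromatic rings, thus gives a read-out level with those of methyl, trifluoromethyl and methoxy within the scatter. No supporting evidence bears on this result.

From the compounds shown here alone, whether any group here can move the read-out beyond the scatter remains open; an amine or a carboxylic acid would test this. Going by these compounds, all four compounds share the rest of the core, so changes elsewhere also remain open.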